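The compounds below may be only part of what the source reports. "The series", "measured", "known", "first", "only" and "open" are said of these compounds alone.

Compound 1 `Cc1ccc(C(C)C)c(OCCSC(=S)N[C@H]2CCOC2=O)c1` and compound 3 `O=C1OCC[C@@H]1NC(=S)SCCOc1cccc2ccccc12` were both tested in a functional assay on MCF7 cells (Homo sapiens) for antiproliferative activity, read by MTT assay, with a stated time of 72 h; a higher number here means a weaker inhibitor, a lower number a stronger inhibitor. For compound 1 the result is only a limit, > 64000 nM. For compound 3 the result is likewise only a limit, > 64000 nM. Among the compounds with values here, compound 2 `O=C(COc1ccc(C(=O)/C=C/c2ccccc2Cl)cc1)N[C@H]1CCOC1=O` is the single compound with a measured number, giving 17400 nM in this assay, while the two other results sit at the limit of > 64000 nM in this assay, at which 2 of the 3 values shown sit. Compound 4 `COc1ccccc1/C=C/C(=O)c1ccc(OCC(=O)N[C@H]2CCOC2=O)cc1` differs from compound 2 by methoxy in place of chloro on an aromatic carbon of a six-membered aromatic ring of carbon only. Within the data shown here, no measured pair shows such an exchange here, so the step from compound 2 to compound 4 is expected to remain within the scatter, the estimated step being a 1.1-fold higher number from compound 2 to compound 4 (0.06 log units; within the scatter). Compound 4 is therefore estimated to give 20000 nM in this assay, with a range from 7000 nM to 60000 nM.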

Compound 4, half-maximal inhibitory concentration: > 64000 nM
Compound 4 was reported as a limit (the forecaster's own chance of this, stated with the estimate: 20%); middle value at least 3.2-fold (0.50 log units) away from the limit.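

In this assay, replacing 2-chlorophenyl with 2-methoxyphenyl gives an at least 3.6-fold higher number from compound 2 to compound 4 (0.56 log units; beyond the scatter), so this place, ortho to a large group, is not indifferent to the exchange. Compound 4 is reported only as a limit, and it joins the other compounds there: the limit of > 64000 nM in this assay, at which 3 of the 4 values shown sit.

Going by these compounds, how large the step really is stays open, since only one end of it is a number. On these data alone, whether a fluoro or an amine at this place would keep the activity of compound 2 also remains open.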